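Nitro for fluoro on the arylidene ring of compound 3

The compounds below may be only part of what the source reports. "The series", "measured", "known", "first", "only" and "open" are said of these compounds alone.

Measured so far in a functional assay on SW 1116 cells (Homo sapiens) for cytotoxicity, read by MTT assay, with a stated time of 48 h; a lower number here means a stronger inhibitor, a higher number a weaker inhibitor:
compound 1 `O=C(CSc1nnc(-c2ccncc2)o1)N/N=C/c1ccc([N+](=O)[O-])cc1` gives 25800 nM;
compound 2 `COc1ccc(/C=N/NC(=O)CSc2nnc(-c3ccncc3)o2)cc1` gives 20300 nM;
compound 3 `O=C(CSc1nnc(-c2ccncc2)o1)N/N=C/c1ccccc1F` gives 21500 nM.

All three share the same core and differ only in the aryl group attached to the carbon with a double bond to nitrogen. Compound 3 sits among the other two rather than apart from them: the step of a 1.2-fold lower number from compound 1 to compound 3 (0.08 log units; within the scatter) and the step of a 1.1-fold higher number from compound 2 to compound 3 (0.02 log units; within the scatter) both fall within the scatter, as does a 1.3-fold lower number from compound 1 to compound 2 (0.10 log units; within the scatter). On these numbers the substituent on that ring has not moved the read-out in any direction that can be trusted.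

Compound 4 `O=C(CSc1nnc(-c2ccncc2)o1)N/N=C/c1ccccc1[N+](=O)[O-]` is the next point. The change from compound 3 is nitro in place of fluoro on an aromatic carbon; cut one bond further out it reads 2-fluorophenyl to 2-nitrophenyl, the nitro entering ortho to a large group.

The step that bears on it most is the comparison of a nitro-bearing ring with others, a 1.3-fold lower number from compound 1 to compound 2 (0.10 log units; within the scatter), and the move between two ring substituents, a 1.1-fold higher number from compound 2 to compound 3 (0.02 log units; within the scatter); neither left the scatter. No step beyond the scatter is therefore expected in this assay, in either direction. The estimated step of a 1.1-fold higher number from compound 3 to compound 4 (0.03 log units; within the scatter) is expected to be small, and compound 4 is estimated at 23000 nM, with a range from 11000 nM to 48000 nM.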

Compound 4, half-maximal inhibitory concentration: 30700 nM
Compound 4: the middle estimate sits 1.3-fold (0.13 log units) below what was measured; measured number inside the range.
By their numbers in this assay, from the lowest: compounds 2, 3, 1 and 4 (each within the scatter of the next).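

In this assay, nitro in place of fluoro on an aromatic carbon, ortho to a large group, gives a 1.4-fold higher number from compound 3 to compound 4 (0.15 log units; within the scatter), so this larger entering group still leaves the read-out within the scatter at this position. The nitro group can also stand in either of the two ring placements shown without a readable difference: 2-nitrophenyl against 4-nitrophenyl gives a 1.2-fold higher number from compound 1 to compound 4 (0.08 log units; within the scatter), and 2-nitrophenyl against 4-methoxyphenyl gives a 1.5-fold higher number from compound 2 to compound 4 (0.18 log units; within the scatter), which also stays within the scatter, leaving all four compounds without a trustworthy order. No measurement available here accounts for how closely these numbers lie.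

On these data alone, it remains open whether an amine or a carboxylic acid on this ring, or a longer chain in place of the aryl group on the carbon with a double bond to nitrogen, would produce a step beyond the scatter. As far as these compounds go, all four compounds also keep the shared core unchanged, so how the read-out responds to changes there remains open as well.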